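The source may report more compounds than this note shows. Statements on the series, on what has been measured and on what is new or still open speak of the compounds shown alone.

Series so far, in a functional assay on BaF3 cells (Mus musculus) for inhibition, read by MTT assay, with a stated time of 3 days; a lower number here means a stronger inhibitor of growth, a higher number a weaker inhibitor of growth:
- compound 1 `O=C(Nc1ccc(Cl)cc1)Nc1ccc(Nc2ncnc3c2OCCN3)cc1`: > 10000 nM
- compound 2 `COc1ccc(NC(=O)Nc2ccc(Nc3ncnc4c3OCCN4)cc2)cc1`: > 10000 nM
- compound 3 `Cc1cc(C)cc(NC(=O)Nc2ccc(Nc3ncnc4c3OCCN4)cc2)c1`: > 10000 nM

Each entry is a limit of the assay and not a number. In this assay compound 3 stands at > 10000 nM, and this too is only a limit. All the measured compounds share this position: the limit of > 10000 nM in this assay, at which 3 of the 3 values shown sit.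

Compound 4 `O=C(Nc1ccc(Nc2ncnc3c2OCCN3)cc1)Nc1cccc2ccccc12` carries naphthalen-1-yl in place of 3,5-dimethylphenyl on an amide-type nitrogen.

The measured steps that bear on this change are a step that the two limits leave unreadable from compound 1 to compound 3 and a step that the two limits leave unreadable from compound 2 to compound 3, both at the same place, and a step that the two limits leave unreadable from compound 1 to compound 2, on the same aryl group. For the measured compounds named here, none gives a size or a direction, so the series offers no measured step to carry over. No aryl group tried so far has given a number, so compound 4 is expected to report a limit as well.

The step expected is a number no higher from compound 3 to compound 4 (the limit leaves the size open), with no change beyond the scatter. Compound 4 is estimated at 10000 nM, with an expected range from 3000 nM to 30000 nM.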

Compound 4, concentration for 50% growth inhibition: > 10000 nM
Compound 4 ended at the assay's limit; the forecaster's own chance of this, stated with the estimate: 75%; the middle value lies on the limit itself.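

In this assay, for the compounds shown here, compound 4 gives > 10000 nM, a limit of the assay and not a number, so no step between compound 4 and compound 1, compound 2 or compound 3 can be read. The compounds shown leave open whether any aryl group on the amide-type nitrogen gives a measurable growth inhibition.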